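Replacing pyridine with thiophene on the benzylic amine

The source may report more compounds than this note shows. Statements on the series, on what has been measured and on what is new or still open speak of the compounds shown alone.

Measured in an ADME assay on Vero cells (Chlorocebus sabaeus) for cytotoxicity, read by MTT assay, with a stated time of 96 h; a lower number here means that less compound is tolerated, a higher number that more compound is tolerated:
Compound 1 `COc1cc(/N=C/c2cccs2)ccc1-c1cnco1` gives 406000 nM
Compound 2 `COc1cc(NCc2ccc(Cl)s2)ccc1-c1cnco1` gives 53800 nM
Compound 3 `COc1cc(NCc2ccncc2)ccc1-c1cnco1` gives 342000 nM

Compound 3 lies within the scatter of compound 1, and a 6.4-fold higher number from compound 2 to compound 3 (0.80 log units; beyond the scatter) sets it clearly apart from compound 2. Among the compounds with values here, compound 4 `COc1cc(NCc2ccsc2)ccc1-c1cnco1` follows from compound 3 with thiophen-3-yl in place of pyridin-4-yl on a saturated chain carbon bound to a nitrogen on an aromatic ring as its only change. Just one measured step bears on this change, namely a 6.4-fold higher number from compound 2 to compound 3 (0.80 log units; beyond the scatter) and it runs from a thiophene group to pyridin-4-yl. Compound 2 carries 5-chlorothiophen-2-yl rather than thiophen-3-yl, so the reverse move is expected to be similar in direction but smaller. The expected change is a 2.1-fold lower number from compound 3 to compound 4 (0.33 log units; beyond the scatter) in this assay by this estimate. Compound 4 is estimated at 160000 nM with an expected range of 55000 nM to 420000 nM overall.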

Compound 4, half-maximal cytotoxic concentration: 181000 nM
Compound 4: middle estimate off by 1.1-fold (0.05 log units), on the low side, within the range that was stated.
By their numbers in this assay, from the lowest: compound 2; then compounds 4, 3 and 1 (each within the scatter of the next, the first and the last beyond it).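

In this assay, thiophen-3-yl and pyridin-4-yl on this saturated chain carbon cannot be told apart, with a 1.9-fold lower number from compound 3 to compound 4 (0.28 log units; within the scatter), so this change of aromatic ring alone does not separate the compounds. Compound 2 does stand apart, with a 3.4-fold higher number from compound 2 to compound 4 (0.53 log units; beyond the scatter), and among the three amines shown only its 5-chlorothiophen-2-yl group does so. Nothing available explains either step.

Going by these compounds, compounds 2 and 4 differ in both the chlorine and the thiophene attachment point, so which of these matters remains open. On these data alone, how a plain phenyl ring or a carboxylic acid would behave at this position also remains open.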